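Compound 1 to compound 3: a side chain cut back

A few compounds are considered here, and "the series" means these few. Any claim that something is new, unique, unknown or untested is made for them only; others in the source may bear on it.

Measured so far in a physicochemical assay for solubility, read by nephelometry; on this read-out higher numbers stand for higher solubility and lower numbers for lower solubility:
- Compound 1 `CN1CCN(CCCC(O)c2ccc(-c3ccc(N4C[C@H](Cn5ccnn5)OC4=O)cc3F)cn2)CC1`: > 400000 nM
- Compound 2 `O=C1O[C@@H](Cn2ccnn2)CN1c1ccc(-c2ccc(C(O)C3CNC3)nc2)c(F)c1`: > 400000 nM

Compound 1 stands at > 400000 nM in this assay, which is a limit of the assay and not a number. Compound 2 gives > 400000 nM, which is also a limit. Together they make up the whole of the measured record: the limit of > 400000 nM in this assay, at which 2 of the 2 values shown sit.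

Compound 3 `CC(C)(O)c1ccc(-c2ccc(N3C[C@H](Cn4ccnn4)OC3=O)cc2F)cn1` carries 1-hydroxy-1-methylethyl in place of 1-hydroxy-4-(4-methylpiperazin-1-yl)butyl on an aromatic carbon of a six-membered aromatic ring with 1 nitrogen (1-hydroxy-1-methylethyl in place of 1-hydroxy-4-(4-methylpiperazin-1-yl)butyl on an aromatic carbon).

Within the data shown here, only one measured step bears on this change: a step that the two limits leave unreadable from compound 1 to compound 2. It replaces 3-(4-methylpiperazin-1-yl)propyl with azetidin-3-yl, but it offers no size to carry over. Among the measured compounds shown here, compound 3 has neither of those groups, so the data contain no measured step of this kind. The expectation therefore rests on the structural change alone: a downward move in this assay, of uncertain size, with a reading at the limit still possible.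

The expected step is an at least 6.6-fold lower number from compound 1 to compound 3 (0.82 log units; beyond the scatter). Compound 3 is estimated at 60000 nM, with an expected range of 10000 nM to 300000 nM.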

Compound 3, solubility: 200000 nM
For compound 3 the middle estimate is 3.3-fold (0.52 log units) below the measured one; the measured number falls inside the stated range.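

In this assay, among these compounds, compound 3 gives 200000 nM, the only value among the three compounds that is not a limit of the assay, so this position now has a measured number. Setting 1-hydroxy-1-methylethyl on the aromatic carbon next to the ring nitrogen, in place of 1-hydroxy-4-(4-methylpiperazin-1-yl)butyl, gives an at least 2.0-fold lower number from compound 1 to compound 3 (0.30 log units; that floor lies within the scatter), and setting it there in place of (azetidin-3-yl)(hydroxy)methyl gives an at least 2.0-fold lower number from compound 2 to compound 3 (0.30 log units; that floor lies within the scatter). Both steps can be stated only as floors, and each floor stays within the usual scatter, because the other two compounds rest at a limit: the limit of > 400000 nM in this assay, at which 2 of the 3 values shown sit.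

From the compounds shown here alone, the true size of either step remains open, as does whether the six-membered ring of compound 1, the azetidine ring of compound 2 or the length of the chain matters most for the reading in this assay. Also open, going by these compounds, is whether a primary amine, a carboxylic acid or a longer chain without a ring at this position would read as a number or at the limit.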